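This account rests on a few compounds, and the source may have more. Where it says the series, first, only, none or still open, it means among the compounds named here.

Measured so far:
compound 1 `C=C1C2=C(C(=O)N1OC)[C@H](OC(=O)CSc1nc3ccccc3s1)[C@@](C)(O)[C@H](CCCCC)O2` — 590 nM
compound 2 `C=C1C2=C(C(=O)N1OC)[C@H](O)[C@@](C)(O)[C@H](CCCCC)O2` — 6500 nM

In a functional assay on NCI-H929 cells (Homo sapiens) for cytotoxicity, read by MTT assay, with a stated time of 72 h (on this read-out higher numbers stand for weaker inhibition and lower numbers for stronger inhibition), compound 1 gives 590 nM, the lowest of the two numbers; compound 2 gives 6500 nM, a gap beyond the scatter. Compound 3 `C=C1C2=C(C(=O)N1OC)[C@H](OC(=O)CSc1nc3ccccc3[nH]1)[C@@](C)(O)[C@H](CCCCC)O2` has not been measured. It differs from compound 1 in one place: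

1H-benzimidazol-2-yl in place of 1,3-benzothiazol-2-yl on a sulfur

Among the measured compounds shown here, no measured step of this kind exists, so the size of the change is open. The expected step of a 1.4-fold higher number from compound 1 to compound 3 (0.13 log units; within the scatter) is small and not clearly beyond the scatter. Compound 3 is estimated at 800 nM, with a range of 300 nM to 2500 nM.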

Compound 3, half-maximal inhibitory concentration: 2000 nM
Estimate against measurement, compound 3: 2.5-fold (0.40 log units) below; measured number inside the range.
By their numbers in this assay, from the lowest: compound 1; then compound 3; then compound 2.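

On a sulfur, the two fused aromatic groups are not interchangeable: in this assay, 1H-benzimidazol-2-yl in place of 1,3-benzothiazol-2-yl gives a 3.4-fold higher number from compound 1 to compound 3 (0.53 log units; beyond the scatter) in this series. The groups match in heavy-atom count and ring types, yet the step lies beyond the scatter, so this position responds to a change within the ring itself. No available data account for the step. Open, as far as these compounds go, is where a 1,3-benzoxazol-2-yl or a plain phenyl group on the same sulfur would fall relative to compound 1 and compound 3.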